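This account rests on a few compounds, and the source may have more. Where it says the series, first, only, none or still open, it means among the compounds named here.

Measured so far:
- compound 1 `Cc1noc(C)c1-c1cccc(Oc2ccc(C#N)c(C(F)(F)F)c2)c1`: "not determined" (no result reported)
- compound 2 `N#Cc1ccc(N2CCCc3c(-c4cccnc4)cccc32)cc1C(F)(F)F`: 10500 nM

In an ADME assay on L02 cells (Homo sapiens) for antiproliferative activity, read by CCK-8 assay, with a stated time of 6 days (a lower number here means a stronger inhibitor, a higher number a weaker inhibitor), compound 2 gives 10500 nM. For the measured compounds named here, this is the only number available, so it cannot yet be ranked against anything, and compound 1 offers no comparison.

The next compound to be read is compound 3 `N#Cc1ccc(N2CCCc3c(-c4ccncc4)cccc32)cc1C(F)(F)F`. It keeps the shared core of compound 2 and changes one substituent: pyridin-4-yl in place of pyridin-3-yl on an aromatic carbon. In words, pyridin-4-yl stands in place of pyridin-3-yl on an aromatic carbon, and the two compounds have the same atoms, joined differently.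

Going by the values given here, no pair of measured compounds shows what a change of this kind does, so the data give no direction for it. The working expectation in this assay is no step beyond the scatter, with compound 2 at 10500 nM as the sole anchor. The expected move is a 1.1-fold lower number from compound 2 to compound 3 (0.02 log units; within the scatter), and the range is kept wide because it rests on a single measurement. For compound 3 the estimated value is 10000 nM, with an expected range of 4000 nM to 25000 nM.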

Compound 3, half-maximal inhibitory concentration: 6380 nM
Estimate against measurement, compound 3: 1.6-fold (0.20 log units) above, within the range that was stated.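

In this assay, for the compounds shown here, the exchange of pyridin-3-yl for pyridin-4-yl gives the first readable step: a 1.6-fold lower number from compound 2 to compound 3 (0.22 log units; within the scatter), for a group on an aromatic carbon of a six-membered aromatic ring of carbon only, part of a fused or bridged system of two rings. The two compounds have the same atoms, joined differently, and this rearrangement within the pyridine substituent does not separate them beyond the usual variation between repeated measurements, so this pair shows no clear sensitivity to the change at this position. No measured evidence is available to account for the result.

The compounds shown leave open whether a group of another kind at the same aromatic carbon, such as an unsubstituted phenyl ring, an amine or a carboxylic acid, would give a step beyond the scatter. They also leave open what the nitrile and trifluoromethyl groups contribute, since both are present in compound 2 and compound 3 alike.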